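Dichlorination of the Benzyl Ether in a Urea Series

A few compounds are considered here, and "the series" means these few. Any claim that something is new, unique, unknown or untested is made for them only; others in the source may bear on it.

Compound 3 `Cc1ccc(NC(=O)NC(=O)c2ccc(OCc3ccccc3)cc2)cc1-c1nc2ccccc2[nH]1` stands second highest of the three numbers in a functional assay on MNK45 cells (Homo sapiens) for inhibition, read by MTT assay, with a stated time of 48 h; a lower number here means a stronger inhibitor, a higher number a weaker inhibitor: compound 3 gives 35100 nM, while compound 1 `Cc1ccc(COc2ccc(C(=O)NC(=S)Nc3ccc(C)c(-c4nc5ccccc5[nH]4)c3)cc2)cc1` gives 11300 nM and compound 2 `Cc1ccc(NC(=S)NC(=O)c2ccc(OCc3cccc(F)c3)cc2)cc1-c1nc2ccccc2[nH]1` gives 86800 nM. Compound 4 `Cc1ccc(NC(=O)NC(=O)c2ccc(OCc3ccc(Cl)c(Cl)c3)cc2)cc1-c1nc2ccccc2[nH]1` differs from compound 3 only by 3,4-dichlorophenyl in place of phenyl on a saturated chain carbon bound to an oxygen on an aromatic ring. Among the measured compounds shown here, the single measured step in this assay, a 7.7-fold higher number from compound 1 to compound 2 (0.89 log units; beyond the scatter), concerns a different pair of groups on the same saturated chain carbon and sits in compounds whose core differs from that of compound 3, so it bears only loosely on the present change. For the measured compounds named here, with no direct precedent, a step beyond the scatter in either direction cannot be ruled out, and the step expected is a 1.2-fold lower number from compound 3 to compound 4 (0.07 log units; within the scatter). Compound 4 is therefore estimated at 30000 nM, in the range 8000 nM to 120000 nM.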

Compound 4, half-maximal inhibitory concentration: 5820 nM
Estimate against measurement, compound 4: 5.2-fold (0.71 log units) above; the measured number lies below the stated range.
By their numbers in this assay, from the lowest: compounds 4 and 1 (each within the scatter of the next); then compound 3; then compound 2.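

In this assay, 3,4-dichlorophenyl in place of phenyl on this saturated chain carbon gives a 6.0-fold lower number from compound 3 to compound 4 (0.78 log units; beyond the scatter), the first step shown here that lowers the number. The earlier step at this carbon, in a different core, went the other way, with a 7.7-fold higher number from compound 1 to compound 2 (0.89 log units; beyond the scatter), so substitution on this ring is not uniformly unfavourable. Nothing measured explains the size of the new step. From the compounds shown here alone, whether a single chlorine, a methoxy group or a trifluoromethyl group would do the same remains open. So does whether the dichlorination carries over to the core of compound 1.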